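Moving the chlorine on the phenyl ring of a thiosemicarbazone

This account rests on a few compounds, and the source may have more. Where it says the series, first, only, none or still open, it means among the compounds named here.

Compound 1 `CC1=CC[C@H](C(C)(C)NC(=S)N/N=C/c2ccccc2)CC1`: 20600 nM
Compound 2 `CC1=CC[C@H](C(C)(C)NC(=S)N/N=C/c2ccc(N(C)C)cc2)CC1`: > 100000 nM
Compound 3 `CC1=CC[C@H](C(C)(C)NC(=S)N/N=C/c2ccccc2Cl)CC1`: 83600 nM

In a functional assay on OVCAR-3 cells (Homo sapiens) for inhibition, read by sulforhodamine B assay, with a stated time of 48 h (on this read-out higher numbers stand for weaker inhibition of growth and lower numbers for stronger inhibition of growth), compound 1 gives 20600 nM. Compound 2 reaches only the limit of the assay, > 100000 nM. Compound 3 stands highest of the two numbers given, its nearest neighbour being compound 1; the step of a 4.1-fold higher number from compound 1 to compound 3 (0.61 log units; beyond the scatter) brought chloro in place of hydrogen on an aromatic carbon. The step of an at least 4.8-fold higher number from compound 1 to compound 2 (0.68 log units; beyond the scatter) put dimethylamino in place of hydrogen and likewise raised the number.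

Compound 4 `CC1=CC[C@H](C(C)(C)NC(=S)N/N=C/c2ccc(Cl)cc2)CC1` differs from compound 3 by 4-chlorophenyl in place of 2-chlorophenyl on a carbon with a double bond to nitrogen. Both measured steps raised the number on substituting the phenyl ring, so a para-chloro is expected to stay near compound 3 or drift somewhat either way, with a 1.4-fold lower number from compound 3 to compound 4 (0.14 log units; within the scatter) expected. Compound 4 is therefore estimated at 60000 nM, between 20000 nM and 150000 nM.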

Compound 4, concentration for total growth inhibition: 26400 nM
The estimate for compound 4 lay 2.3-fold (0.36 log units) above the measured number; low and high end bracket the measured number.
By their numbers in this assay, from the lowest: compounds 1 and 4 (each within the scatter of the next); then compound 3. At a limit, above all of these: compound 2.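

Moving the chlorine matters: with the same atoms joined differently, 4-chlorophenyl in place of 2-chlorophenyl gives a 3.2-fold lower number from compound 3 to compound 4 (0.50 log units; beyond the scatter) and so separates two isomers that the earlier compounds could not compare. Against the unsubstituted phenyl ring, the chloro group in this place no longer shows a change beyond the scatter: a 1.3-fold higher number from compound 1 to compound 4 (0.11 log units; within the scatter). Chloro in place of dimethylamino gives an at least 3.7-fold lower number from compound 2 to compound 4 (0.57 log units; beyond the scatter), a step that starts from a limit: the limit of > 100000 nM in this assay, at which 1 of the 4 values shown sits.

On these data alone, whether a methoxy, a fluoro or a carboxylic acid on the phenyl ring would behave like the chloro of compound 4 or like the dimethylamino of compound 2 stays open.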